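Swapping the acyl aryl group on compound 1

A few compounds are considered here, and "the series" means these few. Any claim that something is new, unique, unknown or untested is made for them only; others in the source may bear on it.

Compound 1 `CN(C(=O)NC(=O)c1ccc(Cl)cc1Cl)c1nc(C(F)(F)F)c(C(=O)N/N=C/c2cccc(C(F)(F)F)c2)s1` is one of three compounds examined in a functional assay on BCG823 cells (Homo sapiens) for inhibition, read by MTT assay, with a stated time of 72 h; a higher number here means a weaker inhibitor, a lower number a stronger inhibitor. In this assay compound 1 gives 6.11 ug/mL, the lowest of the two numbers reported. Compound 3 `Cc1nc(N(C)C(=O)NC(=O)c2c(F)cccc2F)sc1C(=O)N/N=C/c1ccc(C(F)(F)F)cc1` gives 65.5 ug/mL in this assay, a step from compound 1 that lies beyond the usual scatter. Compound 2 `CNc1nc(C(F)(F)F)c(C(=O)N/N=C/c2ccccc2C(F)(F)F)s1` reaches only a limit in this assay, > 100 ug/mL, and not a number; this limit is also noted as the limit of > 100 ug/mL in this assay, at which 1 of the 3 values shown sits.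

Compound 4 `CN(C(=O)NC(=O)c1cccc(C(F)(F)F)c1)c1nc(C(F)(F)F)c(C(=O)N/N=C/c2cccc(C(F)(F)F)c2)s1` has not yet been measured. It differs from compound 1 in one place: 3-(trifluoromethyl)phenyl in place of 2,4-dichlorophenyl on a carbonyl carbon. Among the measured compounds shown here, no step between two measured compounds isolates this change, and the gap between compound 1 and compound 3 involves several differences at once, so it offers no direct guide.

Since the change keeps the carbonyl linkage and the remainder of compound 1 unchanged, a step within or close to the scatter is expected for this assay, with no clear direction. Compound 4 is therefore estimated at 8 ug/mL in this assay, with a plausible range from 3 ug/mL to 25 ug/mL. The expected step from compound 1 to compound 4 is a 1.3-fold higher number from compound 1 to compound 4 (0.12 log units; within the scatter).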

Compound 4, half-maximal inhibitory concentration: 4.6 ug/mL
Beside the measured number, compound 4's estimate is 1.7-fold (0.24 log units) above it; low and high end bracket the measured number.
By their numbers in this assay, from the lowest: compounds 4 and 1 (each within the scatter of the next); then compound 3. At a limit, above all of these: compound 2.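

In this assay, among the compounds shown here, putting 3-(trifluoromethyl)phenyl in place of 2,4-dichlorophenyl on the carbonyl carbon gives a 1.3-fold lower number from compound 1 to compound 4 (0.12 log units; within the scatter), and this is the only step in the set that isolates a single change. It shows that this place, a carbonyl carbon whose other neighbour is an amide-type nitrogen, holds two differently substituted aryl groups without a readable difference in the number, even though one carries chlorine and the other carries fluorine. Nothing reported here accounts for why the two groups read alike.

The compounds shown leave open whether the carbonyl carbon would keep a number in this range with something other than a substituted phenyl group, such as a plain alkyl chain, or with an amine or a carboxylic acid carried on the aryl group. Compound 3 differs from compound 1 in several places at once, so it cannot settle what its own 2,6-difluorinated acyl group contributes at this position.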